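The source may report more compounds than this note shows. Statements on the series, on what has been measured and on what is new or still open speak of the compounds shown alone.

Compound 1, with the structure `COc1cc(OC)c(/C=C/S(=O)(=O)Nc2ccc(OC)c([N+](=O)[O-])c2)c(OC)c1`, and compound 2, with the structure `COc1cc(OC)c(/C=C/S(=O)(=O)Nc2ccc(OC)c(N)c2)c(OC)c1`, share one core and differ in a single place: amino in place of nitro on an aromatic carbon. In a functional assay on K562 cells (Homo sapiens) for cytotoxicity, read by trypan blue exclusion, with a stated time of 96 h (a lower number here means a stronger inhibitor, a higher number a weaker inhibitor), compound 1 gives 1000 nM, while compound 2 gives 3 nM. That change made a step of a 330-fold lower number from compound 1 to compound 2 (2.52 log units; beyond the scatter).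

Compound 3, with the structure `COc1ccc(NS(=O)(=O)/C=C/c2cc(OC)c(OC)c(OC)c2)cc1[N+](=O)[O-]`, is built from the same atoms as compound 1, joined differently; the difference between the two cores is not broken down here. In this assay compound 3 gives 75000 nM, the highest of the three numbers, beyond the scatter from both compound 1 and compound 2.

Compound 4, with the structure `COc1ccc(NS(=O)(=O)/C=C/c2cc(OC)c(OC)c(OC)c2)cc1N`, stands to compound 3 as compound 2 stands to compound 1: amino in place of nitro on an aromatic carbon. The surroundings of the changed position are the same in both pairs, so this is the same change. Resting on the step of a 330-fold lower number from compound 1 to compound 2 (2.52 log units; beyond the scatter), a step of similar size is expected in this assay from compound 3 to compound 4, namely a 250-fold lower number from compound 3 to compound 4 (2.40 log units; beyond the scatter). Compound 4 is therefore expected to give about 300 nM, likely between 50 nM and 3000 nM.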

Compound 4, half-maximal inhibitory concentration: 15000 nM
The estimate for compound 4 lay 50-fold (1.70 log units) below the measured number; the measured number lies above the stated range.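

In this assay, putting amino in place of nitro on the second core again lowers the number, but only modestly, with a step of a 5.0-fold lower number from compound 3 to compound 4 (0.70 log units; beyond the scatter). Set beside the earlier pair, the direction holds while the size does not carry over from one core to the other: the same change on two cores in this assay, a 330-fold lower number (2.52 log units; beyond the scatter) from compound 1 to compound 2 and a 5.0-fold lower number (0.70 log units; beyond the scatter) from compound 3 to compound 4, 67-fold (1.82 log units) apart, beyond the scatter of two such steps. In these two pairs the change lowers the number on both cores, but a step measured on one core proved a poor guide to its size on the other, and two pairs cannot show what in the cores sets that gap or how the change would behave on a further core.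

The compounds shown leave open how other groups would fare at this place, such as a hydroxyl, an acetamide or a dimethylamino group, on either core. Among these compounds, also open is which part of the difference between the two cores goes with the gap in step size, as no compounds here split that difference into single changes.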